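Swapping one stereocentre from R to S

A few compounds are considered here, and "the series" means these few. Any claim that something is new, unique, unknown or untested is made for them only; others in the source may bear on it.

Measured so far in a physicochemical assay for lipophilicity, using the shake flask method, in phosphate buffer, measured as octanol-water partition, at pH 7.4; on this read-out lower numbers stand for lower lipophilicity and higher numbers for higher lipophilicity:
- Compound 1 `CC(C)(C)OC(=O)N1CCN(c2ncc(-c3ccc(OCC#N)cc3)cn2)CC1`: 4.2
- Compound 2 `CC(C)(C)OC(=O)N1CCN(c2ccc(OCc3ccc(S(C)(=O)=O)cc3)nn2)CC1`: 2.8
- Compound 3 `C[C@@H]1CN(c2ncc(OCc3ccc(S(C)(=O)=O)cc3)cn2)CCN1C(=O)OC(C)(C)C`: > 3.7

Compound 1 and compound 2 carry plain numbers. Compound 3 stands at the limit of > 3.7 in this assay, at which 1 of the 3 values shown sits, which is a limit of the assay and not a number.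

The next compound is compound 4 `C[C@H]1CN(c2ncc(OCc3ccc(S(C)(=O)=O)cc3)cn2)CCN1C(=O)OC(C)(C)C`. The change from compound 3 is the two compounds have the same atoms and bonds and differ only in configuration as drawn: 1 of 1 stereo elements differ; a stereocentre at a saturated ring carbon is drawn R in compound 3 and S in compound 4. The two compounds have the same atoms and bonds, and a stereocentre at a saturated ring carbon is drawn R in compound 3 and S in compound 4. Nothing enters and nothing leaves.

With the atoms and bonds unchanged, no step beyond the scatter is expected in this assay, in either direction. The estimated step is a step that the limit leaves unreadable from compound 3 to compound 4. This expectation starts from compound 3 and its limit of > 3.7, so compound 4 may well be reported only as a limit too. For compound 4 the expected value is 3.9, with an estimated range from 3.7 to 4.3.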

Compound 4, distribution coefficient: > 3.6
Compound 4 was reported as a limit (the forecaster's own chance of this, stated with the estimate: 80%); the middle value lies beyond the limit too.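

In this assay, going by these compounds alone, compound 3 and compound 4 are each reported only as a limit and not as a number, and no step between them can be read. As far as these compounds go, whether the R or S configuration at the saturated ring carbon shifts this read-out at all stays open.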